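A few compounds are considered here, and "the series" means these few. Any claim that something is new, unique, unknown or untested is made for them only; others in the source may bear on it.

Compound 1, with the structure `CC(=O)N(C)C(C)C#CCn1ccnc1`, and compound 2, with the structure `CC(=O)N(C)C(C)C#CCn1cncc1C`, were both examined in a functional assay on the whole organism for antagonist activity, with Mus musculus as the target; on this read-out higher numbers stand for an effect only at larger amounts of compound and lower numbers for an effect already at smaller amounts. Compound 1 reaches only the limit of this assay, > 100 mg/kg, which is not a number. In this assay compound 2 gives 80 mg/kg. The two differ only by methyl in place of hydrogen on an aromatic carbon, and this change gave an at least 1.2-fold lower number from compound 1 to compound 2 (0.09 log units; that floor lies within the scatter). The result for compound 1 sits at the limit of > 100 mg/kg in this assay, at which 2 of the 3 values shown sit.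

Compound 3, with the structure `CN1CCN(CC#CCn2ccnc2)C1=O`, has a different core; how its core differs from that of compound 1 is not broken down here. In this assay compound 3 again reaches only the limit, > 100 mg/kg, which is not a number.

Compound 4, with the structure `Cc1cncn1CC#CCN1CCN(C)C1=O`, is not yet measured in this assay. It differs from compound 3 by methyl in place of hydrogen on an aromatic carbon, the same change as that from compound 1 to compound 2. Because that earlier change gave an at least 1.2-fold lower number from compound 1 to compound 2 (0.09 log units; that floor lies within the scatter), the step from compound 3 to compound 4 is expected to be about an at least 1.1-fold lower number from compound 3 to compound 4 (0.04 log units; that floor lies within the scatter). For compound 4 a value of about 90 mg/kg is estimated, from 40 mg/kg to 200 mg/kg.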

Compound 4, dose for half-maximal effect: > 100 mg/kg
Compound 4: a limit, no number (the forecaster's own chance of this, stated with the estimate: 50%); middle value at least 1.1-fold (0.04 log units) away from the limit.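

In this assay compound 4 gives > 100 mg/kg, which is a limit and not a number. Compound 3 also stands at a limit, so no step from compound 3 to compound 4 can be read, and most results shown end at the same point: the limit of > 100 mg/kg in this assay, at which 3 of the 4 values shown sit. The compounds shown leave open whether methyl in place of hydrogen on an aromatic carbon changes the dose needed on the core of compound 3.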